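The source may report more compounds than this note shows. Statements on the series, on what has been measured and on what is new or still open speak of the compounds shown alone.

Going by the values given here, in an assay on CCRF-CEM cells for antagonist activity at C-C chemokine receptor type 4 (Homo sapiens), read by CellTiter-Glo, with stated times of 30 min and 60 min, in the presence of a further agent that is not named here (on this read-out higher numbers stand for weaker inhibition and lower numbers for stronger inhibition), compound 1 `C[C@@H]1CC(c2cnc3c(C#N)nn([C@H](C)c4ccc(Cl)cc4Cl)c3n2)=CC[C@@H]1N1CCC[C@H]1CO` gives 70 nM, the lowest of the two numbers so far; compound 2 `Cc1nn([C@H](C)c2ccc(Cl)cc2Cl)c2nc(C3=CC[C@H](N4CCC[C@H]4CO)[C@H](C)C3)cnc12` gives 179 nM. Among the compounds with values here, the one measured step, a 2.6-fold higher number from compound 1 to compound 2 (0.41 log units; beyond the scatter), concerns the aromatic carbon and not the saturated ring carbon. Compound 3 `C[C@@H]1CC(c2cnc3c(C#N)nn([C@H](C)c4ccc(Cl)cc4Cl)c3n2)=CC[C@@H]1N1CCC[C@H]1C(N)=O` differs from compound 1 by carbamoyl in place of hydroxymethyl on a saturated ring carbon. Within the data shown here, no measured step touches this place, so the expectation rests on the size of the single step seen: a step of similar or smaller size, without a clear direction, tending if anything toward a higher number. The expected step is a 1.4-fold higher number from compound 1 to compound 3 (0.15 log units; within the scatter). Compound 3 is estimated at 100 nM, within a range from 35 nM to 300 nM.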

Compound 3, half-maximal inhibitory concentration: 1380 nM
Beside the measured number, compound 3's estimate is 14-fold (1.14 log units) below it; measured number above the stated range.
By their numbers in this assay, from the lowest: compound 1; then compound 2; then compound 3.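

In this assay, the saturated ring carbon next to the ring nitrogen proves sensitive to the group it carries: carbamoyl in place of hydroxymethyl gives a 20-fold higher number from compound 1 to compound 3 (1.29 log units; beyond the scatter), a larger step than the change on the aromatic carbon, a 2.6-fold higher number from compound 1 to compound 2 (0.41 log units; beyond the scatter). The hydrogen-bond donor and acceptor counts of the two groups are the same, so those counts do not separate them. Nothing available accounts for this step.

Open, going by these compounds, is whether an amine, a carboxylic acid or a longer chain on this carbon would stay near compound 1 at 70 nM. Also open, on these data alone, is whether the same change gives a similar step with methyl on the aromatic carbon, as in compound 2.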